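Amide nitrogen substituents in the trimethoxyphenyl triazole series

This account rests on a few compounds, and the source may have more. Where it says the series, first, only, none or still open, it means among the compounds named here.

Measured so far in a functional assay on the whole organism for inhibition, with Rattus norvegicus as the target, read by paw edema, with stated times of 30 min and 3 h, at a dose of 0.28 mmol/kg by the oral route; a lower number here means less inhibition, a higher number more inhibition at the dose given (going by the name of the read-out):
- compound 1 `CCNC(=O)c1nc(-c2cc(OC)c(OC)c(OC)c2)n(-c2ccc(OC)cc2)n1`: 101%
- compound 2 `COc1ccc(-n2nc(C(=O)Nc3ccccc3OC)nc2-c2cc(OC)c(OC)c(OC)c2)cc1`: 44%
- compound 3 `COc1ccc(-n2nc(C(=O)Nc3ccc(C)cc3)nc2-c2cc(OC)c(OC)c(OC)c2)cc1`: 88%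

Compound 1 stands highest of the three; compound 3 comes nearest, a number 13 percentage points lower from compound 1 to compound 3 (beyond the scatter), and compound 2 lies furthest, a number 57 percentage points lower from compound 1 to compound 2 (beyond the scatter). Between the two aryl amides, a number 44 percentage points higher from compound 2 to compound 3 (beyond the scatter).

Compound 4 `COc1ccc(-n2nc(C(=O)Nc3ccccc3C)nc2-c2cc(OC)c(OC)c(OC)c2)cc1` differs from compound 1 as follows: 2-methylphenyl in place of ethyl on an amide-type nitrogen. Both measured steps from compound 1 bear on this, since each also replaces ethyl with an aryl group on the amide nitrogen; both lowered the read-out, one modestly, one by a large amount. The 2-methylphenyl group shares features with 2-methoxyphenyl of compound 2 and with 4-methylphenyl of compound 3, so a drop of intermediate size is expected, a number 39 percentage points lower from compound 1 to compound 4 (beyond the scatter). Compound 4 is therefore estimated at 62%, with a range of 35% to 90%.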

Compound 4, a percentage reported as inhibition, in the whole organism at one dose (the size of the read-out at that dose, not a potency): 74%
The estimate for compound 4 lay 12 percentage points below the measured number; the range from low to high includes it.
By their numbers in this assay, from the lowest: compound 2; then compound 4; then compound 3; then compound 1.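

In this assay there is a number 27 percentage points lower from compound 1 to compound 4 (beyond the scatter) so all three aryl amides shown stand under the ethyl amide of compound 1. The aryl substituent also matters within this set: there is a number 14 percentage points lower from compound 3 to compound 4 (beyond the scatter) for 2-methylphenyl in place of 4-methylphenyl, and a number 30 percentage points higher from compound 2 to compound 4 (beyond the scatter) for methyl in place of methoxy on an aromatic carbon. No measurement at hand accounts for these steps.

Open, from the compounds shown here alone, is whether a longer chain such as propyl, or an aminoethyl group, on the amide-type nitrogen would hold the level of compound 1. Also open, going by these compounds, is where an unsubstituted phenyl group would fall among the aryl amides.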